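The source may hold more compounds than are shown below. What is called first, only, known or untested is meant among the compounds shown, and "the series" means these compounds.

Within the data shown here, in a functional assay on SMMC-7721 cells (Homo sapiens) for antiproliferative activity, read by MTT assay, with a stated time of 48 h (a lower number here means a stronger inhibitor, a higher number a weaker inhibitor), compound 1 `Cn1cc(C2=C(c3nn(CCCN4CCCCC4)c4ncccc34)C(=O)N(c3ccccc3)C2=O)c2ccccc21` gives 3050 nM, the lowest of the numbers so far. Compound 3 `Cn1cc(C2=C(c3nn(CCCN4CCCCC4)c4ncccc34)C(=O)NC2=O)c2ccccc21` gives 7670 nM. Compound 2 `Cn1cc(C2=C(c3nn(CCCN4CCCCC4)c4ncccc34)C(=O)N(c3ccccn3)C2=O)c2ccccc21` gives only a limit, > 100000 nM.

These three compounds differ solely in the group on an amide-type nitrogen in a ring. Hydrogen in place of phenyl produces a 2.5-fold higher number from compound 1 to compound 3 (0.40 log units; beyond the scatter), while pyridin-2-yl in place of phenyl produces an at least 32-fold higher number from compound 1 to compound 2 (1.51 log units; beyond the scatter).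

Compound 4 `Cn1cc(C2=C(c3nn(CCCn4cccc4)c4ncccc34)C(=O)N(c3ccccc3)C2=O)c2ccccc21` keeps the phenyl and changes a different place: 1H-pyrrol-1-yl in place of piperidin-1-yl on a saturated chain carbon, three bonds along the chain from an aromatic nitrogen. In words, this is 1H-pyrrol-1-yl in place of piperidin-1-yl on a saturated chain carbon, three bonds along the chain from an aromatic nitrogen.

Among the measured compounds shown here, no measured step touches this place, so the earlier steps offer only indirect guidance. They do show that both measured changes away from compound 1 raised the number, and that a single change in this series can matter a great deal. The modest step of a 2.5-fold higher number from compound 1 to compound 3 (0.40 log units; beyond the scatter) is taken as the rough guide, so a modest upward step is expected in this assay, with a larger one remaining possible.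

The step expected here is a 2.0-fold higher number from compound 1 to compound 4 (0.29 log units; within the scatter). For compound 4, the estimated value is 6000 nM, within an expected range of 1500 nM to 30000 nM.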

Compound 4, half-maximal inhibitory concentration: > 100000 nM
Compound 4: no number, only a limit (the forecaster's own chance of this, stated with the estimate: 8%); middle value at least 16-fold (1.22 log units) away from the limit.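

In this assay, the group at the end of the 3-(piperidin-1-yl)propyl chain proves to matter a great deal: 1H-pyrrol-1-yl in place of piperidin-1-yl gives an at least 32-fold higher number from compound 1 to compound 4 (1.51 log units; beyond the scatter). The earlier compounds shown here varied only the group on an amide-type nitrogen in a ring, where pyridin-2-yl in place of phenyl gave an at least 32-fold higher number from compound 1 to compound 2 (1.51 log units; beyond the scatter), and this result shows that a second place on the molecule can produce a step of similar reach while the phenyl stays untouched. The reading for compound 4 is a limit and not a number, so the step has a minimum size but no known true size, and compound 4 cannot be ranked against the other compound that reaches this limit: the limit of > 100000 nM in this assay, at which 2 of the 4 values shown sit.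

This swap changes ring size and aromatic character together, and the compounds shown cannot separate the two. Going by these compounds, a pyrrolidin-1-yl group, a five-membered non-aromatic ring, on the same chain would pull them apart, and how a morpholin-4-yl group, a simple dimethylamino group or a longer chain would behave here also remains open.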